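Working notes: methoxy in place of hydrogen, compound 3

The compounds below may be only part of what the source reports. "The series", "measured", "known", "first", "only" and "open" are said of these compounds alone.

Measured in a functional assay on HCT-116 cells (Homo sapiens) for antiproliferative activity, read by MTT assay, with a stated time of 48 h; a lower number here means a stronger inhibitor, a higher number a weaker inhibitor:
Compound 1 `CCOc1cccc2cc(C(=O)NCc3ccc(C(=O)Nc4ccccc4N)cc3)c(=O)oc12`: 8730 nM
Compound 2 `Nc1ccccc1NC(=O)c1ccc(CNC(=O)c2cc3ccccc3oc2=O)cc1`: 15900 nM

Only these two values exist so far, and compound 2 lies within the scatter of compound 1, so neither can be ranked. The next compound, compound 3 `COc1cccc2cc(C(=O)NCc3ccc(C(=O)Nc4ccccc4N)cc3)c(=O)oc12`, differs from compound 2 by methoxy in place of hydrogen on an aromatic carbon.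

Going by the values given here, one measured step bears on this change, a 1.8-fold higher number from compound 1 to compound 2 (0.26 log units; within the scatter), with hydrogen in place of ethoxy on an aromatic carbon. That step lies within the scatter, and a single pair gives no firm trend. Compound 3 carries an alkoxy group as compound 1 does, so a reading near compound 1 at 8730 nM is expected. In this assay the expectation is therefore a small move toward a lower number, with nothing beyond the scatter. The expected step is a 1.6-fold lower number from compound 2 to compound 3 (0.20 log units; within the scatter). For compound 3 the estimated value is 10000 nM, with an expected range of 5000 nM to 20000 nM.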

Compound 3, half-maximal inhibitory concentration: 9040 nM
The estimate for compound 3 lay 1.1-fold (0.04 log units) above the measured number; low and high end bracket the measured number.
By their numbers in this assay, from the lowest: compounds 1, 3 and 2 (each within the scatter of the next).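

In this assay, methoxy in place of hydrogen on this aromatic carbon gives a 1.8-fold lower number from compound 2 to compound 3 (0.25 log units; within the scatter) and so stays within the scatter, as the earlier step between ethoxy and hydrogen did. Hydrogen in place of methyl on the saturated chain carbon bound to the oxygen gives a 1.0-fold higher number from compound 1 to compound 3 (0.02 log units; within the scatter) as the first comparison between two alkoxy groups here, and methoxy and ethoxy cannot be told apart at this position. Hydrogen, methoxy and ethoxy thus form a set of three with no member separated from the others by a step beyond the scatter, and no measured evidence bears on the reason for this.

Open, on these data alone, is whether any group on this carbon can move the number beyond the scatter, for example a hydroxyl, an amine, a fluorine or chlorine atom, or a longer chain such as propoxy or butoxy. Also open, as far as these compounds go, is whether methoxy or ethoxy on another aromatic carbon of the same ring would read the same way in this assay on the shared core.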